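This account rests on a few compounds, and the source may have more. Where it says the series, first, only, none or still open, it means among the compounds named here.

Of the compounds shown here, three from one series have been measured in a functional assay on VCaP cells (Homo sapiens) for antiproliferative activity, read by CCK-8 assay, with a stated time of 6 days; a lower number here means a stronger inhibitor, a higher number a weaker inhibitor. Compound 1 `N#Cc1ccc(N2CCCc3c(-c4cccnc4)cccc32)cc1C(F)(F)F` gives 13500 nM in this assay. Compound 2 `N#Cc1ccc(N2CCCc3c(-c4ccncc4)cccc32)cc1C(F)(F)F` reaches only the limit of this assay, > 30000 nM, which is a bound rather than a number. Compound 3 `N#Cc1ccc(N2CCc3cc(-c4ccncc4)ccc3C2)cc1C(F)(F)F` gives 3500 nM in this assay and so stands at the lower end of the two numbers given, with compound 1 as its nearest neighbour.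

Compounds 2 and 1 differ in one place, (pyridin-3-yl in place of pyridin-4-yl on an aromatic carbon), and that change yields an at least 2.2-fold lower number from compound 2 to compound 1 (0.34 log units; beyond the scatter). This rests on the fact that compound 2 sits at the bound described by the limit of > 30000 nM in this assay, at which 1 of the 3 values shown sits, so only a minimum size of the step can be stated. How the core of compound 3 differs from the core of compound 2 is not broken down here.

Compound 4 `N#Cc1ccc(N2CCc3cc(-c4cccnc4)ccc3C2)cc1C(F)(F)F` has not yet been measured. It relates to compound 3 by pyridin-3-yl in place of pyridin-4-yl on an aromatic carbon. The surroundings are not the same as in the earlier pair: in compound 1 the group sits ortho to a fused ring and meta to a fused ring, whereas in compound 4 it sits meta to a fused ring and para to a fused ring, so this is the same kind of change rather than the same change. Set beside the earlier step, the step from compound 3 to compound 4 in this assay is expected to be a 1.9-fold lower number from compound 3 to compound 4 (0.29 log units; within the scatter), resting on the direction seen from compound 2 to compound 1 an at least 2.2-fold lower number from compound 2 to compound 1 (0.34 log units; beyond the scatter). Compound 4 is therefore estimated to give 1800 nM in this assay, expected to fall between 600 nM and 5000 nM.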

Compound 4, half-maximal inhibitory concentration: 2530 nM
Estimate against measurement, compound 4: 1.4-fold (0.15 log units) below; measured number inside the range.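

For the compounds shown here, on the core of compound 3, pyridin-3-yl in place of pyridin-4-yl gives a 1.4-fold lower number from compound 3 to compound 4 (0.14 log units; within the scatter) in this assay, so on this core the change produces no step that can be told apart from the usual scatter of repeated measurements. On the core of compound 1 the same change gave a step beyond the scatter, so the second core does not repeat that result, yet the two steps cannot be said to differ in size: the same change on two cores in this assay, an at least 2.2-fold lower number (0.34 log units; beyond the scatter) from compound 2 to compound 1 and a 1.4-fold lower number (0.14 log units; within the scatter) from compound 3 to compound 4; the limit leaves it open whether they differ. The data therefore show neither that the change carries from one core to the other with a fixed size nor that its size depends on the core, and the earlier step remains only a minimum, resting on a value of compound 2 that is a limit: the limit of > 30000 nM in this assay, at which 1 of the 4 values shown sits.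

The compounds shown leave open how other groups would behave at the same aromatic carbon on either core, for example pyridin-2-yl, an unsubstituted phenyl ring or a carboxylic acid. They also leave open whether this change would give a step beyond the scatter on the core of compound 3 if the nitrile or the trifluoromethyl group were replaced by, for example, an amide or a chlorine atom.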